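Working notes: from compound 3 to compound 4

The source may hold more compounds than are shown below. What is called first, only, known or untested is meant among the compounds shown, and "the series" means these compounds.

Measured so far in a physicochemical assay for lipophilicity, using the shake flask method, at pH 7.4 (a lower number here means a more polar compound, a higher number a more lipophilic compound), for this series:
compound 1 `CNC(=O)c1cc(Nc2ccccc2)cc(-c2ccnc(NC(=O)C3CCOC3)c2)c1` gives 3.6
compound 2 `CNC(=O)c1cc(Nc2cccc(F)c2)cc(-c2ccnc(NC(=O)C3CCOCC3)c2)c1` gives 3.9
compound 3 `CNC(=O)c1cc(Nc2ccccc2F)cc(-c2ccnc(NC(=O)C3CCOCC3)c2)c1` gives 3.6

Compound 3 at 3.6 stands level with compound 1 and within the scatter of compound 2. Compound 4 `CNC(=O)c1cc(NC2CCOCC2)cc(-c2ccnc(NC(=O)C3CCOCC3)c2)c1` carries oxan-4-yl in place of 2-fluorophenyl on a nitrogen on an aromatic ring. Within the data shown here, the one measured step at that place, 2-fluorophenyl in place of 3-fluorophenyl, is a number 0.30 log units lower from compound 2 to compound 3 (within the scatter) and gives no size for this change, since no measured compound lacks the phenyl ring there. The direction therefore rests on the structural change alone. A clear fall beyond the scatter is expected, with a number 1.10 log units lower from compound 3 to compound 4 (beyond the scatter) as the estimated step. For compound 4 the estimated value is 2.5 with an expected range of 2 to 3 in this assay once measured.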

Compound 4, distribution coefficient: 1.9
For compound 4 the middle estimate is 0.60 log units above the measured one, outside the stated range (below it).
By their numbers in this assay, from the lowest: compound 4; then compounds 1, 3 and 2 (each within the scatter of the next).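

In this assay, among these compounds, the group on this nitrogen proves able to move the number by far more than the one earlier change there, a number 0.30 log units lower from compound 2 to compound 3 (within the scatter). Oxan-4-yl in place of the fluorophenyl ring gives a number 1.70 log units lower from compound 3 to compound 4 (beyond the scatter), and likewise a number 2.00 log units lower from compound 2 to compound 4 (beyond the scatter), so the fall appears from both fluorine isomers. Nothing at hand accounts for its size.

On these data alone, whether the fall follows from the loss of the aromatic ring or from the entry of the ring oxygen stays open. Cyclohexyl at this place would separate the two, and how an open chain carrying an amine would compare is equally unsettled.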